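Methyl branching in the propargylamine carbamate series: limits only

The compounds below may be only part of what the source reports. "The series", "measured", "known", "first", "only" and "open" are said of these compounds alone.

Compound 1, `COC(=O)N(C)CC#CCn1ccnc1`, is examined in a functional assay on the whole organism for antagonist activity, with Mus musculus as the target; a lower number here means that less compound is needed, a higher number that more compound is needed for the effect. In this assay compound 1 gives only a limit, > 100 mg/kg. Compound 2, `COC(=O)N(C)C(C)C#CCn1ccnc1`, likewise gives only a limit in this assay, > 100 mg/kg. The change from compound 1 to compound 2 is methyl in place of hydrogen on a saturated chain carbon bound to an amide-type nitrogen and a triple-bonded carbon, and the step it made in this assay, a step that the two limits leave unreadable from compound 1 to compound 2, cannot be read because both ends are limits. Compound 3, `CCOC(=O)N(C)CC#CCN1CCCC1`, carries a different core; the difference between the core of compound 1 and the core of compound 3 is not broken down here. In this assay compound 3 also gives only a limit, > 100 mg/kg. Going by the values given here, every value measured so far sits at the limit of > 100 mg/kg in this assay, at which 3 of the 3 values shown sit.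

Compound 4, `CCOC(=O)N(C)C(C)C#CCN1CCCC1`, has not yet been measured. It differs from compound 3 by methyl in place of hydrogen on a saturated chain carbon bound to an amide-type nitrogen and a triple-bonded carbon, the same change as that from compound 1 to compound 2. With both earlier values at the limit of > 100 mg/kg in this assay, at which 3 of the 3 values shown sit, the step from compound 3 to compound 4 in this assay is expected to be small, a step that the limit leaves unreadable from compound 3 to compound 4. Compound 4 is expected to give 150 mg/kg, most probably reported again as a limit.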

Compound 4, dose for half-maximal effect: > 100 mg/kg
Compound 4: a limit, no number (the forecaster's own chance of this, stated with the estimate: 85%); the middle value is on the limit's open side.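

Compound 3 and compound 4 both give only limits, so the step between them cannot be read in this assay and no new comparison arises. All values shown sit at one limit: the limit of > 100 mg/kg in this assay, at which 4 of the 4 values shown sit.

The compounds shown leave open whether methyl in place of hydrogen on this saturated chain carbon alters the dose required in either pair, and what dose any of the four compounds requires.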